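Pyrazine to pyridazine on the sulfonamide nitrogen: solubility outlook

This account rests on a few compounds, and the source may have more. Where it says the series, first, only, none or still open, it means among the compounds named here.

Compounds measured in a physicochemical assay for solubility; a higher number here means a more soluble compound, a lower number a less soluble compound:
compound 1 `Cn1nccc1-c1cc(C(F)(F)F)ccc1[C@H]1CCOc2cc(S(=O)(=O)Nc3cccc(F)n3)ccc21` gives 27000 nM
compound 2 `Cn1nccc1-c1cc(C(F)(F)F)ccc1[C@H]1CCOc2cc(S(=O)(=O)Nc3ccc(F)cn3)ccc21` gives 29000 nM
compound 3 `Cn1nccc1-c1cc(C(F)(F)F)ccc1[C@H]1CCOc2cc(S(=O)(=O)Nc3cnccn3)ccc21` gives 1170000 nM

Compound 3 stands highest of the three in this assay. Its nearest neighbour is compound 2, as a 40-fold higher number from compound 2 to compound 3 (1.61 log units; beyond the scatter) shows, and compound 1 lies furthest, as a 43-fold higher number from compound 1 to compound 3 (1.64 log units; beyond the scatter) shows. Between compounds 1 and 2 the difference is a 1.1-fold higher number from compound 1 to compound 2 (0.03 log units; within the scatter).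

Compound 4 `Cn1nccc1-c1cc(C(F)(F)F)ccc1[C@H]1CCOc2cc(S(=O)(=O)Nc3cccnn3)ccc21` is not yet measured. It differs from compound 3 in one place: pyridazin-3-yl in place of pyrazin-2-yl on a sulfonamide nitrogen.

Among the compounds with values here, no measured step covers this particular exchange. The two large steps into compound 3 both replace a fluoropyridinyl group by pyrazin-2-yl, whereas the step from compound 1 to compound 2, which exchanges one fluoropyridinyl for another, stays within the scatter. The move to pyridazin-3-yl keeps the same atoms and the same count of acceptors, so it sits closer in kind to the small step than to the large ones, yet the direction is not fixed by any shown pair. Compound 4 is therefore expected to give a somewhat lower number than compound 3, with a 2.9-fold lower number from compound 3 to compound 4 (0.47 log units; beyond the scatter) as the expected step, though a result within the scatter would not surprise. The estimate for compound 4 is 400000 nM, with a range from 80000 nM to 1500000 nM.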

Compound 4, solubility: 915000 nM
Compound 4: the middle estimate sits 2.3-fold (0.36 log units) below what was measured, within the range that was stated.
By their numbers in this assay, from the lowest: compounds 1 and 2 (each within the scatter of the next); then compounds 4 and 3 (each within the scatter of the next).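

In this assay, putting pyridazin-3-yl in place of pyrazin-2-yl on the sulfonamide nitrogen gives a 1.3-fold lower number from compound 3 to compound 4 (0.11 log units; within the scatter), so this read-out does not separate these two groups, which have the same atoms joined differently. The large steps seen earlier are therefore no longer tied to pyrazin-2-yl alone, since pyridazin-3-yl in place of the fluoropyridinyl groups gives a 32-fold higher number from compound 2 to compound 4 (1.50 log units; beyond the scatter) and a 34-fold higher number from compound 1 to compound 4 (1.53 log units; beyond the scatter). Among the four compounds shown, the numbers now fall into two sets, with compounds 1 and 2 on one side and compounds 3 and 4 on the other, and no compound shown goes against this split.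

No measurement shown accounts for the split, so what lies behind it remains unexplained. From the compounds shown here alone, it also stays open whether numbers at the level of compounds 3 and 4 would be reached with pyrimidin-2-yl or an unsubstituted pyridin-2-yl on the sulfonamide nitrogen, and whether the same exchanges would give steps of similar size on a core other than the shared one.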